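Swapping in Benzyl on the Ring Amine of Compound 3

This account rests on a few compounds, and the source may have more. Where it says the series, first, only, none or still open, it means among the compounds named here.

- Compound 1 `Cc1cccc(NC(=O)[C@H]2CN(C)C[C@@H]2c2ccc(/C=C/C(=O)Nc3ccccc3N)cc2)c1`: 74 mL/min/kg
- Compound 2 `CN1C[C@H](C(=O)Nc2ccc(F)cc2F)[C@@H](c2ccc(/C=C/C(=O)Nc3ccccc3N)cc2)C1`: 27 mL/min/kg
- Compound 3 `CC(C)(CO)N1C[C@H](C(=O)Nc2ccc(Cl)cc2)[C@@H](c2ccc(/C=C/C(=O)Nc3ccccc3N)cc2)C1`: 40 mL/min/kg
- Compound 4 `Nc1ccccc1NC(=O)/C=C/c1ccc([C@H]2CN(Cc3ccccc3)C[C@@H]2C(=O)Nc2ccc(Cl)cc2)cc1`: not yet measured

The three measured compounds were tested in an in vitro ADME assay on microsomes from liver (Mus musculus) for pharmacokinetics, read by LC-MS, with a stated time of 10 min, tested at 1 uM; a lower number here means slower removal, a higher number faster removal of the compound. There, compound 3 gives 40 mL/min/kg, a number within the scatter of both compound 1 and compound 2, although those two differ from each other beyond it. Compound 4 carries benzyl in place of 1-(hydroxymethyl)-1-methylethyl on an amine nitrogen in a ring. Within the data shown here, no measured step touches that nitrogen. Among the measured compounds shown here, the only measured step, a 2.7-fold lower number from compound 1 to compound 2 (0.44 log units; beyond the scatter), is modest and beyond the scatter, but it lies on an amide-type nitrogen, so it serves only as a rough gauge of size. On that gauge, a rise in this assay no larger than that step is expected, possibly one that stays within the scatter. For the measured compounds named here, the upward direction is a judgement on the swap itself, and no measured pair tests it. The expected step is a 1.6-fold higher number from compound 3 to compound 4 (0.21 log units; within the scatter). For compound 4 the estimate is 65 mL/min/kg, with an expected range from 35 mL/min/kg to 110 mL/min/kg.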

Compound 4, clearance: 81 mL/min/kg
Compound 4: the middle estimate sits 1.2-fold (0.10 log units) below what was measured, within the range that was stated.
By their numbers in this assay, from the lowest: compounds 2, 3, 1 and 4 (each within the scatter of the next, the first and the last beyond it).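

Among these compounds, replacing 1-(hydroxymethyl)-1-methylethyl with benzyl on the amine nitrogen in the ring gives, in this assay, a 2.0-fold higher number from compound 3 to compound 4 (0.31 log units; beyond the scatter), the first measured step at this position. The group on this nitrogen therefore moves the read-out beyond the scatter, and this step is modest, as is the one on the amide-type nitrogen, a 2.7-fold lower number from compound 1 to compound 2 (0.44 log units; beyond the scatter), so neither place yet stands out as the larger lever on clearance among these compounds. The swap takes away a group with a hydrogen-bond donor and a hydrogen-bond acceptor and brings in a six-membered aromatic ring of carbon only, and nothing available says which of these differences accounts for the step.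

Still open, from the compounds shown here alone, is whether the step follows the arrival of the aromatic ring or the loss of the hydroxyl, a question that a tert-butyl or a cyclohexylmethyl group on this nitrogen would help to separate. The compounds shown also leave open how a methyl on this nitrogen compares with benzyl when the (4-chlorophenyl)carbamoyl group stays in place, since compounds 1 and 2 carry other amides.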